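This account rests on a few compounds, and the source may have more. Where it says the series, first, only, none or still open, it means among the compounds named here.

Compound 2, `CC(C)=CCOc1c(C)c(C)c2c(c1C)CCC(C)(COc1ccc(/C=C3\SC(=O)NC3=O)cc1)O2`, stands at the weaker end of the two measured compounds in a functional assay on MCF7 cells (Homo sapiens), tested at 2.5 uM; on this read-out lower numbers stand for a stronger effect and higher numbers for a weaker effect at the one concentration tested: compound 2 gives 76%, the highest of the two numbers. Compound 1, `C=CCOc1c(C)c(C)c2c(c1C)CCC(C)(COc1ccc(/C=C3\SC(=O)NC3=O)cc1OC)O2`, gives 34% in this assay, a number below that of compound 2 by more than the usual scatter. Compound 3, `COc1cc(/C=C2\SC(=O)NC2=O)ccc1OCC1(C)CCc2c(C)c(OCC=C(C)C)c(C)c(C)c2O1`, has not yet been measured in this assay. Its change from compound 2 is methoxy in place of hydrogen on an aromatic carbon. For the measured compounds named here, no measured pair differs in only this one place, so the size of this step has not been seen directly. Compound 1 also carries a methoxy group, but it differs from compound 2 in a second place as well, so its number is only a loose guide. The step from compound 2 to compound 3 is expected to be a number 21 percentage points lower from compound 2 to compound 3 (beyond the scatter), a drop in the number and thus a stronger effect. Compound 3 is estimated at 55%, with a range from 30% to 80%.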

Compound 3, a percentage reported as activity, at one concentration (the size of the read-out at that concentration, not a potency): 95%
Compound 3: the middle estimate sits 40 percentage points below what was measured; the measured number lies above the stated range.
By their numbers in this assay, from the lowest: compound 1; then compound 2; then compound 3.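

In this assay, methoxy in place of hydrogen on an aromatic carbon, ortho to a large group, can now be read alone, and it gives a number 19 percentage points higher from compound 2 to compound 3 (beyond the scatter), so at this position the change weakens the effect at the one concentration tested. With methoxy present in both compounds, 2-methylprop-1-en-1-yl in place of vinyl gives a number 61 percentage points higher from compound 1 to compound 3 (beyond the scatter), a larger step, which ties the low number of compound 1 to its vinyl end rather than to its methoxy group. Nothing in the data at hand explains either step.

From the compounds shown here alone, whether methoxy moves the number the same way on a compound with the vinyl end remains open. So does whether a hydroxyl group or a fluorine atom on that aromatic carbon, or a saturated propyl chain at the ether end, would behave like the groups shown.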